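The compounds below may be only part of what the source reports. "The series", "measured", "known", "first", "only" and "open" are said of these compounds alone.

In a physicochemical assay for lipophilicity, read by HPLC (a higher number here means a more lipophilic compound, a lower number a more polar compound), compound 1 (`COc1ccc(NC[C@@H](O)COc2ccc(N3C[C@H](CNC(C)=O)OC3=O)cc2F)cc1`) gives 1.15 and compound 2 (`CC(=O)NC[C@H]1CN(c2ccc(OC[C@@H](O)CNc3ccccn3)c(F)c2)C(=O)O1`) gives 1.37, while compound 3 (`CC(=O)NC[C@H]1CN(c2ccc(OC[C@H](O)CNc3cccnc3)c(F)c2)C(=O)O1`) gives -0.18 as the lowest of the three numbers. Compound 4 (`CC(=O)NC[C@H]1CN(c2ccc(OC[C@H](O)CNC3CC3)c(F)c2)C(=O)O1`) carries cyclopropyl in place of pyridin-3-yl on an amine nitrogen. Among the measured compounds shown here, no measured step makes this exact exchange. The closest is pyridin-3-yl in place of 4-methoxyphenyl on the same amine nitrogen, which gave a number 1.33 log units lower from compound 1 to compound 3 (beyond the scatter) as the first step bearing on it. The exchange of pyridin-2-yl for pyridin-3-yl within the amino side chain gave a number 1.55 log units lower from compound 2 to compound 3 (beyond the scatter) as the second. Both steps are large, so the range around any expectation has to stay wide. For the measured compounds named here, both also start from an aromatic group and end at compound 3, and no measured compound has cyclopropyl on that nitrogen, so the data give no firm direction. In this assay no step beyond the scatter is therefore expected, with only a slight lean upward since compound 3 at -0.18 stands lowest so far. The expected step is a number 0.18 log units higher from compound 3 to compound 4 (within the scatter) on this reading. The estimate for compound 4 is an expected 0 with -0.7 to 0.7 as its range.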

Compound 4, partition coefficient: -0.1
For compound 4 the middle estimate is 0.10 log units above the measured one; the range from low to high includes it.
By their numbers in this assay, from the lowest: compounds 3 and 4 (each within the scatter of the next); then compounds 1 and 2 (each within the scatter of the next).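

In this assay cyclopropyl in place of pyridin-3-yl on the amine nitrogen gives a number 0.08 log units higher from compound 3 to compound 4 (within the scatter), so a three-membered ring of carbon only, with no hydrogen-bond acceptor, reads like the six-membered aromatic ring with 1 hetero atom. The low number at this position is therefore not unique to pyridin-3-yl: cyclopropyl in place of 4-methoxyphenyl gives a number 1.25 log units lower from compound 1 to compound 4 (beyond the scatter), and 2-(cyclopropylamino)-1-hydroxyethyl in place of 1-hydroxy-2-((pyridin-2-yl)amino)ethyl gives a number 1.47 log units lower from compound 2 to compound 4 (beyond the scatter), so large steps now separate both compound 1 and compound 2 from a non-aromatic as well as an aromatic substituent. No measurement at hand accounts for why these two quite different groups read alike, or why the other two stand apart.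

Open, on these data alone, is how a plain phenyl on the same amine nitrogen would read, which would separate the contribution of the methoxy group in 4-methoxyphenyl from that of the ring. Also open, as far as these compounds go, is whether a longer chain such as n-butyl, or a larger saturated ring such as cyclohexyl, would stay with cyclopropyl or move toward the higher numbers.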